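Series notes: from compound 2 to compound 3

This account rests on a few compounds, and the source may have more. Where it says the series, first, only, none or still open, it means among the compounds named here.

- compound 1 `O=C(Oc1ccccc1)C1(S(=O)(=O)c2ccc(Oc3ccc(OC(F)(F)F)cc3)cc2)CCC2(CCNCC2)C1` gives 3900 nM in an ADME assay on THLE-2 cells (Homo sapiens) for cytotoxicity, read by luminescence, with a stated time of 72 h; on this read-out higher numbers stand for lower toxicity in this test and lower numbers for higher toxicity in this test
- compound 2 `Nc1ccccc1NC(=O)C1(S(=O)(=O)c2ccc(Oc3ccc(OC(F)(F)F)cc3)cc2)CCC2(CCNCC2)C1` gives 7220 nM in this assay
- compound 3 `CNC(=O)NC(=O)C1(S(=O)(=O)c2ccc(Oc3ccc(OC(F)(F)F)cc3)cc2)CCC2(CCNCC2)C1` has no measurement yet

Among the measured compounds shown here, only one measured step exists in this assay and it is a 1.9-fold higher number from compound 1 to compound 2 (0.27 log units; within the scatter), so compound 2 cannot be separated from the other measured compound. The change under consideration leads to compound 3 and reads (methylcarbamoyl in place of 2-aminophenyl on an amide-type nitrogen), which puts methylcarbamoyl in place of 2-aminophenyl on an amide-type nitrogen. The measured step bears on this only indirectly. For the measured compounds named here, it altered the group on the same carbonyl carbon and stayed within the scatter, while no measured pair shows the removal of 2-aminophenyl itself. On that thin evidence, the expected change is a 1.1-fold higher number from compound 2 to compound 3 (0.04 log units; within the scatter) and nothing beyond the scatter is anticipated. For compound 3 the estimated value is 8000 nM in this assay, with an expected range from 3000 nM to 22000 nM for repeat measurements.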

Compound 3, concentration lethal to 50% of the cells: 16200 nM
For compound 3 the middle estimate is 2.0-fold (0.31 log units) below the measured one, and the stated range covers the measured number.
By their numbers in this assay, from the lowest: compounds 1 and 2 (each within the scatter of the next); then compound 3.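

In this assay, among the compounds shown here, methylcarbamoyl in place of 2-aminophenyl on an amide-type nitrogen gives a 2.2-fold higher number from compound 2 to compound 3 (0.35 log units; beyond the scatter) and is the first step beyond the scatter, so the number does respond to the group at this position. With (methylcarbamoyl)amino in place of phenoxy on a carbonyl carbon, the result is a 4.2-fold higher number from compound 1 to compound 3 (0.62 log units; beyond the scatter) as well, so in these two steps the loss of the six-membered aromatic ring goes with a higher number. No measured information here accounts for either step.

The compounds shown do not separate the loss of the aromatic ring from the entry of the methylcarbamoyl carbonyl. Going by these compounds, how a simple amine or a carboxylic acid on the same carbonyl carbon, or a longer chain in place of the methyl group, would read in this assay remains open.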